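Taking the nitro group off compound 2

The source may report more compounds than this note shows. Statements on the series, on what has been measured and on what is new or still open speak of the compounds shown alone.

- compound 1 `COc1ccc(C(=O)/C=C/c2ccc(Br)cc2)c2c1C=CC(C)(C)O2`: > 10000 nM (a limit, not a number)
- compound 2 `COc1ccc(C(=O)/C=C/c2cccc([N+](=O)[O-])c2)c2c1C=CC(C)(C)O2`: 8050 nM

Going by the values given here, in a functional assay on HCT-116 cells (Homo sapiens) for antiproliferative activity, read by MTT assay, with a stated time of 24 h (on this read-out lower numbers stand for stronger inhibition and higher numbers for weaker inhibition), compound 2 gives 8050 nM, the only true number in this small set. Compound 1 gives > 10000 nM, and this is a limit of the assay. So there is little to compare with: the limit of > 10000 nM in this assay, at which 1 of the 2 values shown sits.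

The next compound is compound 3 `COc1ccc(C(=O)/C=C/c2ccccc2)c2c1C=CC(C)(C)O2`, which has hydrogen in place of nitro on an aromatic carbon, so that 3-nitrophenyl becomes phenyl: hydrogen in place of nitro on an aromatic carbon.

Among the compounds with values here, only one measured step bears on this change, because it alters the same phenyl group: an at least 1.2-fold lower number from compound 1 to compound 2 (0.09 log units; that floor lies within the scatter). That step shows no change beyond the scatter, so it gives no reason to expect a large shift in this assay. The expected step is a 1.1-fold higher number from compound 2 to compound 3 (0.05 log units; within the scatter), which would be no real step beyond the scatter. The assay may well report only a limit again. For compound 3 the estimated value is 9000 nM, with an expected range from 3500 nM to 20000 nM.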

Compound 3, half-maximal inhibitory concentration: > 10000 nM
Compound 3: a limit, no number (the forecaster's own chance of this, stated with the estimate: 45%); middle value at least 1.1-fold (0.04 log units) away from the limit.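

In this assay, with hydrogen in place of nitro on the aromatic carbon, so that 3-nitrophenyl becomes phenyl, compound 3 gives > 10000 nM, which is a limit and not a number. The size of this change is therefore known only as a floor, an at least 1.2-fold higher number from compound 2 to compound 3 (0.09 log units; that floor lies within the scatter), and the true step could be no larger than the scatter or could be much larger. The step between compound 1 and compound 3 cannot be read, so the plain phenyl adds a second compound without a number and compound 2 remains the only one with a true value: the limit of > 10000 nM in this assay, at which 2 of the 3 values shown sit.

As far as these compounds go, whether the nitro group contributes anything real to the activity of compound 2 stays open, since a single number close to a limit gives little to measure against. Also open, from the compounds shown here alone, is what an amine or a carboxylic acid on that same aromatic carbon would give, and whether either would yield a true number in this assay.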